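A few compounds are considered here, and "the series" means these few. Any claim that something is new, unique, unknown or untested is made for them only; others in the source may bear on it.

In a functional assay on the whole organism for inhibition, with Rattus norvegicus as the target, read by cytopathic effect and paw edema, at a dose of 100 mg/kg by the oral route (on this read-out lower numbers stand for less inhibition and higher numbers for more inhibition at the one dose given (going by the name of the read-out)), the measured compounds are:
compound 1 `CCOC(=O)c1c(O)c2cccnc2n(-c2ccccc2)c1=O`, which gives 15.5%;
compound 2 `O=C(NC1CCN(Cc2ccccc2)CC1)c1c(O)c2cccnc2n(-c2ccccc2)c1=O`, which gives 1.2%;
compound 3 `O=C(Nc1cccc(Cl)c1)c1c(O)c2cccnc2n(-c2ccccc2)c1=O`, which gives 13.4%.

Compound 3 stands second highest of the three. Its nearest neighbour is compound 1, separated by a number 2.1 percentage points lower from compound 1 to compound 3 (within the scatter), a gap within the scatter. Compound 2 lies furthest, and the two values differ beyond the scatter. Compound 4 `O=C(Nc1ccc(Cl)nc1)c1c(O)c2cccnc2n(-c2ccccc2)c1=O` differs from compound 3 by 6-chloropyridin-3-yl in place of 3-chlorophenyl on an amide-type nitrogen. Among the measured compounds shown here, only one measured step touches the amide end of this core, the change from ethoxy to (3-chlorophenyl)amino, which gave a number 2.1 percentage points lower from compound 1 to compound 3 (within the scatter) and stayed within the scatter. For the measured compounds named here, no measured step swaps one aromatic ring for another on the amide-type nitrogen, so compound 4 is expected to show no step beyond the scatter, a number 1.4 percentage points lower from compound 3 to compound 4 (within the scatter). Compound 4 is therefore estimated at 12%, from 3% to 22%.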

Compound 4, a percentage reported as inhibition, in the whole organism at one dose (the size of the read-out at that dose, not a potency): -4%
Beside the measured number, compound 4's estimate is 16 percentage points above it; measured number below the stated range.
By their numbers in this assay, from the lowest: compounds 4 and 2 (each within the scatter of the next); then compounds 3 and 1 (each within the scatter of the next).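

In this assay, among the compounds shown here, the ring on the amide-type nitrogen proves to matter: 6-chloropyridin-3-yl in place of 3-chlorophenyl gives a number 17.4 percentage points lower from compound 3 to compound 4 (beyond the scatter), whereas the one earlier step at this end of the core, a number 2.1 percentage points lower from compound 1 to compound 3 (within the scatter), did not leave the scatter. Set against ethoxy, (6-chloropyridin-3-yl)amino gives a number 19.5 percentage points lower from compound 1 to compound 4 (beyond the scatter), so on this carbonyl carbon the outcome depends on which aromatic ring the amide carries. Nothing available explains why this exchange of rings has such an effect. On these data alone, whether a plain pyridin-3-yl without the chlorine, or a 3-methoxyphenyl, would stay with compound 3 or fall with compound 4 remains open.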